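Chain length trimmed and a chlorine added at the ether

The source may hold more compounds than are shown below. What is called first, only, known or untested is meant among the compounds shown, and "the series" means these compounds.

The series shares a bicyclic amino diacid core carrying an ether on a saturated carbon. Compound 1 `CO[C@@H]1C[C@@H]2[C@H]([C@]1(N)C(=O)O)[C@@]2(F)C(=O)O` gives 39.2 nM in an assay on CHO cells for binding affinity to metabotropic glutamate receptor 2 (Rattus norvegicus); on this read-out lower numbers stand for stronger inhibition and higher numbers for weaker inhibition. Compound 2 `CCC(C)O[C@@H]1C[C@@H]2[C@H]([C@]1(N)C(=O)O)[C@@]2(F)C(=O)O` gives 6.68 nM. Compound 3 `N[C@]1(C(=O)O)[C@H]2[C@@H](C[C@H]1OCCCc1ccccc1)[C@]2(F)C(=O)O` gives 9.83 nM, the second highest number of the three; its gap to compound 2 lies within the scatter, while its gap to compound 1 lies beyond it. Both measured steps point the same way: a 5.9-fold lower number from compound 1 to compound 2 (0.77 log units; beyond the scatter) and a 4.0-fold lower number from compound 1 to compound 3 (0.60 log units; beyond the scatter), so a larger group on the ether oxygen has twice lowered the number by a modest amount.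

Compound 4 `N[C@]1(C(=O)O)[C@H]2[C@@H](C[C@H]1OCc1cccc(Cl)c1)[C@]2(F)C(=O)O` differs from compound 3 in one place: 3-chlorophenyl in place of phenethyl on a saturated chain carbon bound to an oxygen on a saturated carbon. The aromatic ring is kept but the chain between oxygen and ring is shortened, and a chlorine is added. Neither measured step isolates chain length or a halogen, so the expectation rests on the general trend that a group of this size on the ether keeps the number low. The step of a 1.0-fold higher number from compound 3 to compound 4 (0.01 log units; within the scatter) is expected to stay within the scatter. Compound 4 is therefore estimated at 10 nM, with a range from 4 nM to 25 nM.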

Compound 4, inhibition constant: 3.28 nM
Beside the measured number, compound 4's estimate is 3.0-fold (0.48 log units) above it; measured number below the stated range.
By their numbers in this assay, from the lowest: compound 4; then compounds 2 and 3 (each within the scatter of the next); then compound 1.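

In this assay, a 3.0-fold lower number from compound 3 to compound 4 (0.48 log units; beyond the scatter) shows that this position still responds after an aromatic ring is already in place: phenethyl and 3-chlorophenyl each carry one six-membered aromatic ring of carbon only, and the lower number comes with the group of 7 heavy atoms rather than the group of 8, so here it does not follow the larger heavy-atom count. Over the whole series, a 12-fold lower number from compound 1 to compound 4 (1.08 log units; beyond the scatter) is the first large step on the ether, whereas the earlier steps from the methyl ether of compound 1 were modest. The evidence available gives no account of why 3-chlorophenyl gives the lower number, and the shorter link to the ring and the added chlorine arrive together in this single step, so their shares cannot be told apart.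

What the compounds shown leave open is how an unsubstituted benzyl group would read on the same oxygen, which would separate the chain change from the chlorine. They also leave open whether the chlorine could give way to a fluorine, a bromine or a methoxy group with the number staying as low as that of compound 4.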